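Working notes: methoxy in place of hydrogen on compound 2

The source may report more compounds than this note shows. Statements on the series, on what has been measured and on what is new or still open speak of the compounds shown alone.

Values in a functional assay on A549 cells (Homo sapiens) for inhibition, read by MTT assay, with a stated time of 24 h; a lower number here means a stronger inhibitor of growth, a higher number a weaker inhibitor of growth 
- compound 1 `COc1ccc(C(=O)n2c(-c3cn(C)c4ccccc34)nc3ccccc32)cc1` gives 10400 nM 
- compound 2 `Cn1cc(-c2nc3ccccc3n2C(=O)c2ccccc2)c2cc(Br)ccc21` gives 23100 nM 

At 23100 nM compound 2 has the higher of the two numbers, and compound 1 lies lower, beyond the usual scatter. Compound 3 `COc1ccc(C(=O)n2c(-c3cn(C)c4ccc(Br)cc34)nc3ccccc32)cc1` differs from compound 2 in one place methoxy in place of hydrogen on an aromatic carbon and has methoxy in place of hydrogen on an aromatic carbon, which turns benzoyl into (4-methoxyphenyl)carbonyl. Among the compounds with values here, no measured pair isolates this change. Compound 1 also carries (4-methoxyphenyl)carbonyl and gives 10400 nM in this assay but differs from compound 2 in more than one place, so it offers only a weak guide. A modest move to a lower number is expected, estimated as a 1.7-fold lower number from compound 2 to compound 3 (0.22 log units; within the scatter) and perhaps no larger than the scatter. Compound 3 is estimated at 14000 nM within a range of 6000 nM to 30000 nM in this assay until it is measured.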

Compound 3, concentration for 50% growth inhibition: 11300 nM
Compound 3: middle estimate off by 1.2-fold (0.09 log units), on the high side; low and high end bracket the measured number.
By their numbers in this assay, from the lowest: compounds 1 and 3 (each within the scatter of the next); then compound 2.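

The change from benzoyl to (4-methoxyphenyl)carbonyl now has a matched pair in this assay, on the core carrying bromo: it gives a 2.0-fold lower number from compound 2 to compound 3 (0.31 log units; beyond the scatter) and so is a modest step just beyond the scatter. With (4-methoxyphenyl)carbonyl held fixed, bromo in place of hydrogen on an aromatic carbon gives a 1.1-fold higher number from compound 1 to compound 3 (0.04 log units; within the scatter) and stays within the scatter, so compound 1 and compound 3 cannot be told apart here. Nothing available bears on the origin of the methoxy step.

Methoxy is the only group compared with hydrogen at this position, so the outcome with a hydroxyl, an amine or a longer chain such as ethoxy remains open. Also open is whether the methoxy step recurs on the core without bromo, since the compounds shown offer no matched pair for it.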